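The source may hold more compounds than are shown below. What is called first, only, known or untested is meant among the compounds shown, and "the series" means these compounds.

Values so far in an ADME assay on HCT-116 cells (Homo sapiens) for antiproliferative activity; on this read-out higher numbers stand for weaker inhibition and lower numbers for stronger inhibition:
compound 1 (`COc1ccc(C(C)=O)cc1COc1cccc(C)c1`): 24000 nM
compound 2 (`COc1ccc(C(N)=O)cc1/C=C/c1ccc(C(C)(C)C)cc1`): 20000 nM

Compound 2 at 20000 nM lies within the scatter of compound 1, so these two values give no ranking. Within the data shown here, both sit in the same range, and that range is the only guide available for the next compound.

Compound 3 (`COc1ccc(/C=C/c2cc(C(N)=O)ccc2OC)cc1`) is compound 2 with one change (methoxy in place of tert-butyl on an aromatic carbon): methoxy in place of tert-butyl on an aromatic carbon, para to a large group.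

Among the measured compounds shown here, no measured pair differs in one place, so the data hold no precedent for this change. No step beyond the scatter is expected in this assay, and neither direction is favoured. The estimate means a 1.1-fold lower number from compound 2 to compound 3 (0.05 log units; within the scatter) as the expected step, with a wide margin on both sides.

In this assay compound 3 is estimated at 18000 nM (expected range 5000 nM to 60000 nM).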

Compound 3, half-maximal inhibitory concentration: 19000 nM
Compound 3: the middle estimate sits 1.1-fold (0.02 log units) below what was measured; low and high end bracket the measured number.
By their numbers in this assay, from the lowest: compounds 3, 2 and 1 (each within the scatter of the next).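

In this assay, among these compounds, methoxy in place of tert-butyl on an aromatic carbon, para to a large group, gives a 1.1-fold lower number from compound 2 to compound 3 (0.02 log units; within the scatter) and provides the first pair that differs in one place. At this position, the read-out does not separate the two groups, although methoxy has 2 heavy atoms against 4 for tert-butyl and brings 1 hydrogen-bond acceptor where tert-butyl has none. No accompanying evidence bears on this result.

Going by these compounds, whether an amine or a carboxylic acid at this position would move the number beyond the scatter remains open. The compounds shown also leave open what a carboxylic acid in place of the primary amide would do, since that group is the same in compound 2 and compound 3.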